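Cyano for Benzoyl in a Cytotoxicity Series

The source may hold more compounds than are shown below. What is called first, only, known or untested is meant among the compounds shown, and "the series" means these compounds.

Compound 1 `C=C[C@@](C)(/C=C/c1ccc(O)cc1)CC/C=C/C(=O)c1ccccc1` and compound 2 `C=C[C@@](C)(/C=C/c1ccc(O)cc1)CC/C=C/C#N` share one core and differ in a single change, (cyano in place of benzoyl on a double-bonded chain carbon bound to a double-bonded chain carbon). In an ADME assay on HEK293 cells (Homo sapiens) for cytotoxicity, with a stated time of 72 h (a lower number here means that less compound is needed, a higher number that more compound is needed for the effect), compound 1 gives only a limit, > 36600 nM. Compound 2 likewise gives only a limit in this assay, > 36600 nM. The step that the two limits leave unreadable from compound 1 to compound 2 is therefore unreadable, since both values sit at the limit of > 36600 nM in this assay, at which 2 of the 3 values shown sit. Compound 3 `C=C[C@@](C)(/C=C/c1ccc(O)c(/C=C/C(=O)c2ccccc2)c1)CCC=C(C)C` carries a core whose difference from the core of compound 1 is not broken down here. In this assay compound 3 also gives only a limit, > 7410 nM, namely (the limit of > 7410 nM in this assay, at which 1 of the 3 values shown sits). Compound 4 `C=C[C@@](C)(/C=C/c1ccc(O)c(/C=C/C#N)c1)CCC=C(C)C` derives from compound 3 by the same change, (cyano in place of benzoyl on a double-bonded chain carbon bound to a double-bonded chain carbon), at the same place. For the measured compounds named here, every value shown so far is a limit, so no measured step gives a size for this change. A step that the limit leaves unreadable from compound 3 to compound 4 is expected because a step that the two limits leave unreadable from compound 1 to compound 2 lies between two limits and shows no sign of movement. Compound 4 is estimated to give 40000 nM, within 7410 nM to 200000 nM, most likely reported again as a limit.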

Compound 4, half-maximal effective concentration: > 36600 nM
Compound 4: no number, only a limit; the forecaster's own chance of this, stated with the estimate: 85%; the middle value is on the limit's open side.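

In this assay compound 3 and compound 4 each give only a limit, so the step between them cannot be read. The compounds shown leave open whether cyano in place of benzoyl changes the half-maximal effective concentration at all and, if it does, in which direction and by how much.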